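Benzyl in place of methyl on the sulfur of compound 1

This account rests on a few compounds, and the source may have more. Where it says the series, first, only, none or still open, it means among the compounds named here.

Compound 1 `CSc1nc(=O)ccn1[C@@H]1O[C@H](COP(=O)(O)OP(=O)(O)O)[C@@H](O)[C@H]1O` is the strongest of the three measured compounds: in an in vitro functional assay on 1321-N1 cells for agonist activity at P2Y purinoceptor 2 (Homo sapiens), read by scintillation proximity assay and inositol phosphate accumulation (on this read-out lower numbers stand for an effect already at smaller amounts and higher numbers for an effect only at larger amounts of compound), compound 1 gives 523 nM, and both of its steps to the others lie beyond the scatter. Compound 2 `O=c1ccn([C@@H]2O[C@H](COP(=O)(O)O)[C@@H](O)[C@H]2O)c(SCCc2ccccc2)n1` gives 1300 nM, and compound 3 `CSc1nc(=O)ccn1[C@@H]1O[C@H](COP(=O)(O)O)[C@@H](O)[C@H]1O` gives 2900 nM. Compound 4 `O=c1ccn([C@@H]2O[C@H](COP(=O)(O)OP(=O)(O)O)[C@@H](O)[C@H]2O)c(SCc2ccccc2)n1` differs from compound 1 by phenyl in place of hydrogen on a saturated chain carbon bound to a sulfur, that is, methylsulfanyl becomes benzylsulfanyl while the diphosphate is kept. Within the data shown here, two measured steps bear on this. The step of a 5.5-fold higher number from compound 1 to compound 3 (0.74 log units; beyond the scatter) shows that the second phosphate matters, but compound 4 keeps it, so that step does not enter. The step of a 2.2-fold higher number from compound 2 to compound 3 (0.35 log units; beyond the scatter) shows that removing a benzyl group from the same chain carbon raised the number moderately, so adding a phenyl at that carbon is expected to lower it by a comparable amount. Compound 4 is therefore estimated at 250 nM, within 90 nM to 700 nM, a step of a 2.1-fold lower number from compound 1 to compound 4 (0.32 log units; beyond the scatter) that is expected to be modest.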

Compound 4, half-maximal effective concentration: 6200 nM
Compound 4: the middle estimate sits 25-fold (1.39 log units) below what was measured; the measured number lies above the stated range.
By their numbers in this assay, from the lowest: compound 1; then compound 2; then compound 3; then compound 4.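

At this position the phenyl is far from neutral: in this assay, methylsulfanyl to benzylsulfanyl with the diphosphate kept gives a 12-fold higher number from compound 1 to compound 4 (1.07 log units; beyond the scatter), a large loss and the biggest step among the compounds shown. The earlier step on the monophosphate side, a 2.2-fold higher number from compound 2 to compound 3 (0.35 log units; beyond the scatter), had pointed the other way, with the larger sulfur substituent giving the lower number, so that direction does not carry over to this change on the diphosphate of compound 1. Nothing measured here accounts for the loss.

The compounds shown leave open whether the rise in number sets in gradually, as ethylsulfanyl or propylsulfanyl in place of methylsulfanyl would show. They also leave open whether benzylsulfanyl would raise the number on the monophosphate of compound 3 as well, or whether a carboxylic acid on the phenyl would change the outcome.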